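The source may report more compounds than this note shows. Statements on the series, on what has been measured and on what is new or still open speak of the compounds shown alone.

Compound 1 `CCc1cc2c(C(=O)c3ccc(OC)cc3)cc(OC)cc2o1` and compound 2 `CCc1oc2cc(OC)ccc2c1C(=O)c1ccc(O)cc1` are two ketones built on different cores; the difference between the two cores is not broken down here. Compound 3 `CCc1oc2cc(O)ccc2c1C(=O)c1ccc(O)cc1` shares the core of compound 2, and compound 4 `CCc1cc2c(C(=O)c3ccc(O)cc3)cc(OC)cc2o1` shares the core of compound 1.

In an assay for inhibition of solute carrier family 22 member 12 (Homo sapiens), read by scintillation counting, with a stated time of 60 min (a higher number here means a weaker inhibitor, a lower number a stronger inhibitor), compound 1 gives "not determined" (no result reported), so its result is not known. In this assay compound 2 gives 3920 nM, while compound 3 gives 1130 nM. The change from compound 2 to compound 3 is hydrogen in place of methyl on an oxygen on an aromatic ring, and it made a step of a 3.5-fold lower number from compound 2 to compound 3 (0.54 log units; beyond the scatter) in this assay.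

The change from compound 1 to compound 4 is hydrogen in place of methyl on an oxygen on an aromatic ring. The place around it reads the same as in the change from compound 2 to compound 3, so it is the same change, though carried out on the core of compound 1 rather than that of compound 2. In this assay the step from compound 1 to compound 4 is therefore expected to be of a similar size to the step seen from compound 2 to compound 3, resting on a 3.5-fold lower number from compound 2 to compound 3 (0.54 log units; beyond the scatter). Because compound 1 gives "not determined" (no result reported), there is no starting number on its core, so the estimate can only be carried over from the measured pair.

Compound 4 is expected to show about 2500 nM in this assay, with the estimated range running from 500 nM to 12000 nM.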

Compound 4, half-maximal inhibitory concentration: 19700 nM
Compound 4: middle estimate off by 7.9-fold (0.90 log units), on the low side; the whole stated range lies below it.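

In this assay, going by these compounds alone, compound 1 gives "not determined" (no result reported), so no step from compound 1 to compound 4 can be read. The compounds shown leave open whether methoxy to hydroxy changes the number on the core of compound 1 as it does on the core of compound 2. No measurement shown here offers an explanation for the result of compound 4.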